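Aryl in place of alkynol at the pyridine carbon

A few compounds are considered here, and "the series" means these few. Any claim that something is new, unique, unknown or untested is made for them only; others in the source may bear on it.

Compound 2 `Nc1ccc(S(=O)(=O)N2CCN(c3ncc(C(O)(C(F)(F)F)C(F)(F)F)cc3C#CCCO)CC2)cn1` is tested in an ADME assay (liver) for metabolic stability, with Liver microsome (Rattus norvegicus) as the target, using microsomes and NADPH, with a stated time of 30 min, tested at 1 uM (on this read-out lower numbers stand for slow clearance and higher numbers for fast clearance), where compound 2 gives 68 mL.min-1.g-1. Among the three compounds measured, compound 2 stands second highest: compound 1 `Nc1ccc(S(=O)(=O)N2CCN(c3ncc(C(O)(C(F)(F)F)C(F)(F)F)cc3C#CCO)CC2)cn1`, which gives 65 mL.min-1.g-1 in this assay, is the nearest, with a 1.0-fold higher number from compound 1 to compound 2 (0.02 log units; within the scatter), so the two cannot be told apart; compound 3 `CCn1cc(-c2cc(C(O)(C(F)(F)F)C(F)(F)F)cnc2N2CCN(S(=O)(=O)c3ccc(N)nc3)CC2)cn1`, which gives 194 mL.min-1.g-1 in this assay, is the furthest, with a 2.9-fold higher number from compound 2 to compound 3 (0.46 log units; beyond the scatter).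

Compound 4 `NC(=O)c1cccc(-c2cc(C(O)(C(F)(F)F)C(F)(F)F)cnc2N2CCN(S(=O)(=O)c3ccc(N)nc3)CC2)c1` has not been measured in this assay. It differs from compound 2 in one place: 3-carbamoylphenyl in place of 4-hydroxybut-1-yn-1-yl on an aromatic carbon. The change that bears on this is the replacement of the chain by a ring at the same aromatic carbon: a 2.9-fold higher number from compound 2 to compound 3 (0.46 log units; beyond the scatter) and, from the shorter chain, a 3.0-fold higher number from compound 1 to compound 3 (0.47 log units; beyond the scatter). Both steps are modest and point the same way. Going by the values given here, the group entering in compound 4 is a different aromatic ring from the one in compound 3, and no measured step shows how that ring itself behaves, so the direction is taken from the two steps and the size is uncertain.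

Compound 4 is therefore expected to give 170 mL.min-1.g-1 in this assay, between 80 mL.min-1.g-1 and 360 mL.min-1.g-1, a step of a 2.5-fold higher number from compound 2 to compound 4 (0.40 log units; beyond the scatter) that is estimated to lie beyond the scatter.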

Compound 4, intrinsic clearance in microsomes: 63 mL.min-1.g-1
Beside the measured number, compound 4's estimate is 2.7-fold (0.43 log units) above it; the measured number lies below the stated range.
By their numbers in this assay, from the lowest: compounds 4, 1 and 2 (each within the scatter of the next); then compound 3.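

In this assay a ring at this aromatic carbon does not by itself go with the higher number: 3-carbamoylphenyl cannot be told apart from 4-hydroxybut-1-yn-1-yl (a 1.1-fold lower number from compound 2 to compound 4 (0.03 log units; within the scatter)) or from 3-hydroxyprop-1-yn-1-yl (a 1.0-fold lower number from compound 1 to compound 4 (0.01 log units; within the scatter)). The gap lies between the two rings (a 3.1-fold lower number from compound 3 to compound 4 (0.49 log units; beyond the scatter)), so compound 3 with its 1-ethyl-1H-pyrazol-4-yl group stands apart from the other three compounds, and the earlier rise from chain to ring holds for that ring only. No measurement given here accounts for the difference between the two rings.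

Compound 3 and compound 4 differ in both the aromatic ring and the group it carries, so the compounds shown do not separate the effect of the ring from that of the ethyl or carbamoyl group. As far as these compounds go, an unsubstituted phenyl, a 1-methyl-1H-pyrazol-4-yl group or a phenyl ring bearing a carboxylic acid in place of the carbamoyl group would stand closer to one of these two compounds, and how any of them reads at this aromatic carbon remains open.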